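The source may hold more compounds than are shown below. What is called first, only, known or untested is meant among the compounds shown, and "the series" means these compounds.

Measured compounds so far:
Compound 1, `O=S(=O)(Nc1ccc(-c2nc3ccccc3o2)cc1)c1cccc(Cl)c1`, gives in an assay on isolated protein for inhibition of malate dehydrogenase, mitochondrial (Sus scrofa), with stated times of 45 min and 30 min (a higher number here means a weaker inhibitor, a lower number a stronger inhibitor), a value of > 63000 nM, which is a limit of the assay and not a number.
Compound 2, `C=Cc1ccc(S(=O)(=O)Nc2ccc3oc(-c4ccccc4)nc3c2)cc1`, gives in this assay a value of > 63000 nM, again a limit.
Compound 3, `O=S(=O)(Nc1ccc(-c2nc3ccccc3o2)cc1)c1cccc(C(F)(F)F)c1`, gives in this assay a value of > 63000 nM, also a limit.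

Compound 1 therefore stands nowhere in particular on these numbers: only a limit is known for it, and the same holds for the two other measured compounds, as the limit of > 63000 nM in this assay, at which 3 of the 3 values shown sit, records. Going by the values given here, the one step between measured compounds that differ in a single place, a step that the two limits leave unreadable from compound 1 to compound 3, is unreadable for that reason; its size cannot be told.

Compound 4, `COc1ccccc1S(=O)(=O)Nc1ccc(-c2nc3ccccc3o2)cc1`, is not yet measured. It differs from compound 1 by 2-methoxyphenyl in place of 3-chlorophenyl on a sulfonyl sulfur. Among the compounds with values here, no measured step shows what this change does, so there is nothing to read a direction or size from, and the step that the limit leaves unreadable from compound 1 to compound 4 that the estimate below means is therefore expected to be none beyond the scatter. Compound 4 is expected to give about 100000 nM in this assay, within the range 30000 nM to 300000 nM, and most likely only a limit will be reported for compound 4 once more.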

Compound 4, half-maximal inhibitory concentration: > 63000 nM
Compound 4 gave a limit, no number; the forecaster's own chance of this, stated with the estimate: 85%; the middle value lies beyond the limit too.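

Compound 1 and compound 4 both give only a limit and no number, so no step between them can be read: the limit of > 63000 nM in this assay, at which 4 of the 4 values shown sit.

The compounds shown leave open whether any of these structures inhibits the enzyme to a measurable degree in this assay, and how compound 1, compound 2, compound 3 and compound 4 would truly compare.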